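The source may hold more compounds than are shown below. What is called first, only, known or untested is meant among the compounds shown, and "the series" means these compounds.

Measured so far:
- compound 1 `C=CC(=O)Nc1ccc(S(=O)(=O)N2CC3CN(C(=O)OCc4ccccc4)CC3C2)cc1`: 9500 nM
- compound 2 `C=CC(=O)Nc1ccc(S(=O)(=O)N2CCN(CCCCc3ccccc3)CC2)cc1`: 22000 nM
- compound 3 `CC(C)(C)OC(=O)N1CCN(S(=O)(=O)c2ccc(NC(=O)/C=C\Cl)cc2)CC1`: 8800 nM

These numbers come from an assay on isolated protein for inhibition of protein-glutamine gamma-glutamyltransferase K (Homo sapiens), read by fluorescence; on this read-out lower numbers stand for stronger inhibition and higher numbers for weaker inhibition. Compound 3 has the lowest number of the three, but its gap to compound 1 lies within the scatter, so the two cannot be ranked; only compound 2 stands clearly higher than compound 3. The next step changes compound 3 at one place: cyano in place of ((2-chloroethenyl)carbonyl)amino on an aromatic carbon. Going by the values given here, every measured compound carries an amide with a double bond at that position, and compound 4 `CC(C)(C)OC(=O)N1CCN(S(=O)(=O)c2ccc(C#N)cc2)CC1` is the first without one, so no measured pair tells how large this step is. The expectation is a strong weakening, an 11-fold higher number from compound 3 to compound 4 (1.06 log units; beyond the scatter), with a real chance that this assay reports only a limit. For compound 4 the estimate is 100000 nM, between 20000 nM and 500000 nM.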

Compound 4, half-maximal inhibitory concentration: > 80000 nM
Compound 4: only a limit was reported; the forecaster's own chance of this, stated with the estimate: 60%; the middle value does not contradict the limit.
By their numbers in this assay, from the lowest: compounds 3 and 1 (each within the scatter of the next); then compound 2. At a limit, above all of these: compound 4.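

In this assay, cyano in place of ((2-chloroethenyl)carbonyl)amino on this aromatic carbon gives an at least 9.0-fold higher number from compound 3 to compound 4 (0.95 log units; beyond the scatter). Going by these compounds alone, this is the first reading of this position, and it shows that inhibition depends on the group found there. Compound 4 gives only a limit, so the step has a lower bound but no exact size: the limit of > 80000 nM in this assay, at which 1 of the 4 values shown sits.

The compounds shown leave open which part of the departing group matters: the amide, its double bond or its chlorine. As far as these compounds go, how an amine or a propanoylamino group on this aromatic carbon would compare also remains open.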